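Chain length on the diphenyl core, sigma-1 binding

The source may hold more compounds than are shown below. What is called first, only, known or untested is meant among the compounds shown, and "the series" means these compounds.

Compound 1 `NCC[C@@H]1CCOC(c2ccccc2)(c2ccccc2)O1`: > 10000 nM
Compound 2 `NCCC[C@@H]1CCO[C@H](c2ccccc2)O1`: 167 nM
Compound 3 `CN(C)CCC[C@@H]1CCO[C@H](c2ccccc2)O1`: 1220 nM

In an assay for displacement of a labelled ligand from Sigma non-opioid intracellular receptor 1 (Cavia porcellus), read by scintillation counting (on this read-out higher numbers stand for weaker inhibition and lower numbers for stronger inhibition), compound 1 gives > 10000 nM, which is a limit of the assay and not a number. Compound 1 thus stands at the limit of > 10000 nM in this assay, at which 1 of the 3 values shown sits, leaving no measured value from which a step can be anchored. Among the compounds with values here, compound 2 gives 167 nM and compound 3 gives 1220 nM in this assay; the single measured step, a 7.3-fold higher number from compound 2 to compound 3 (0.86 log units; beyond the scatter), concerns the amine substitution and not the chain length. Compound 4 `NCCC[C@@H]1CCOC(c2ccccc2)(c2ccccc2)O1` differs from compound 1 by aminomethyl in place of amino on a saturated chain carbon, two bonds along the chain from a saturated ring carbon. Within the data shown here, no measured step bears directly on this change. Among the measured compounds shown here, compound 2 carries the same three-carbon chain but also a different core, so its value shows only that a compound with such a chain can sit well inside the measurable range. The step expected is an at least 3.3-fold lower number from compound 1 to compound 4 (0.52 log units; beyond the scatter), from the limit toward a measurable number, with wide uncertainty. Compound 4 is estimated at 3000 nM, between 500 nM and 20000 nM.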

Compound 4, inhibition constant: 175 nM
Estimate against measurement, compound 4: 17-fold (1.23 log units) above; measured number outside the range, below it.
By their numbers in this assay, from the lowest: compounds 2 and 4 (each within the scatter of the next); then compound 3. At a limit, above all of these: compound 1.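

In this assay, aminomethyl in place of amino on a saturated chain carbon, two bonds along the chain from a saturated ring carbon, gives an at least 57-fold lower number from compound 1 to compound 4 (1.75 log units; beyond the scatter) on the core of compound 1. This shows that a change in chain length alone takes this core from the limit into the measurable range, and that the position does not tolerate every chain length equally. The value of compound 1 is > 10000 nM in this assay, which is a limit of the assay and not a number, so the step is bounded on one side only: the limit of > 10000 nM in this assay, at which 1 of the 4 values shown sits.

On these data alone, whether a longer chain or a carboxylic acid in place of the amine on the core of compound 4 would hold a measurable number in this assay stays open. Also open, as far as these compounds go, is whether dimethylamino on that core would repeat a 7.3-fold higher number from compound 2 to compound 3 (0.86 log units; beyond the scatter) on the core of compound 2.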